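An Unmeasured Bromine Swap Against Three Cytotoxicity Limits

A few compounds are considered here, and "the series" means these few. Any claim that something is new, unique, unknown or untested is made for them only; others in the source may bear on it.

Of the compounds shown here, three have been measured, all in an ADME assay on HEK-293T cells (Homo sapiens) for cytotoxicity, with a stated time of 48 h; on this read-out lower numbers stand for higher toxicity in this test and higher numbers for lower toxicity in this test.
Compound 1, `CCc1ncnc(NC(C)c2ccc(C(C)(C)C)cc2)c1Cl`, gives > 10000 nM, which is a limit of the assay rather than a number.
Compound 2, `CCc1ncnc(NC(CC)c2ccc(C(C)(C)C)cc2)c1Cl`, gives > 10000 nM, again a limit of the assay.
Compound 3, `CCCc1cc(NC(CC)c2ccc(Oc3ccc(F)cc3)cc2)ncn1`, gives > 10000 nM, also a limit of the assay.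

Compound 3 thus stands exactly where every measured compound stands, at the limit of > 10000 nM in this assay, at which 3 of the 3 values shown sit, so the numbers shown do not separate it from compound 1 or compound 2. Among the compounds with values here, the one change between measured compounds, a step that the two limits leave unreadable from compound 1 to compound 2, cannot be read either: both of its ends are limits.

Compound 4, `CCc1ncnc(NC(CC)c2ccc(Oc3ccc(F)cc3)cc2)c1Br`, is the compound still to be tested. It differs from compound 3 by 5-bromo-6-ethylpyrimidin-4-yl in place of 6-propylpyrimidin-4-yl on an amine nitrogen. Within the data shown here, this change sits on a different part of the molecule from the change between compound 1 and compound 2, and no measured step in this assay speaks to it directly; the only guide is that all three measured compounds sit at the limit. The expected step is therefore a step that the limit leaves unreadable from compound 3 to compound 4, meaning nothing readable in this assay. For compound 4 the estimate is 15000 nM, with a range from 7000 nM to 40000 nM, and the most likely report is once more a limit rather than a number.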

Compound 4, half-maximal cytotoxic concentration: > 10000 nM
Compound 4 ended at the assay's limit (the forecaster's own chance of this, stated with the estimate: 85%); the middle value does not contradict the limit.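

No step can be read from compound 3 to compound 4 in this assay, since both ends are limits of the assay rather than numbers: the limit of > 10000 nM in this assay, at which 4 of the 4 values shown sit.

The compounds shown leave open whether 5-bromo-6-ethylpyrimidin-4-yl in place of 6-propylpyrimidin-4-yl on an amine nitrogen alters the read-out in this assay at all.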